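Cytotoxicity notes: dimethylcarbamoyl in place of 3,4-dimethoxyphenyl

The compounds below may be only part of what the source reports. "The series", "measured", "known", "first", "only" and "open" are said of these compounds alone.

Compound 1 (`CCOC(=O)c1cc(CCCOc2ccc(-c3noc(C(F)(F)F)n3)cc2[N+](=O)[O-])on1`): (> 100000 nM), a limit and not a number
Compound 2 (`COc1ccc(-c2cc(CCCOc3c(C)cc(-c4noc(C(F)(F)F)n4)cc3C)on2)cc1OC`): (41900 nM)

Both readings come from (an ADME assay on HeLa cells (Homo sapiens) for cytotoxicity, read by crystal violet staining, with a stated time of 72 h; a higher number here means that more compound is tolerated, a lower number that less compound is tolerated). Among the compounds with values here, compound 2 gives the only actual number in the set (41900 nM), so it cannot yet be ranked against another number. The other reading is a limit (the limit of > 100000 nM in this assay, at which 1 of the 2 values shown sits).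

Compound 3 (`Cc1cc(-c2noc(C(F)(F)F)n2)cc(C)c1OCCCc1cc(C(=O)N(C)C)no1`) shares the core of compound 2 and differs from it in one place, on an aromatic carbon of a five-membered aromatic ring with 1 nitrogen and 1 oxygen. There, dimethylcarbamoyl stands in place of 3,4-dimethoxyphenyl (dimethylcarbamoyl in place of 3,4-dimethoxyphenyl on an aromatic carbon). Within the data shown here, no measured step isolates this change, since compound 1 and compound 2 differ in more than one place, so the expectation is tentative.

In (this assay) a modest upward step is expected, meaning that more compound would be tolerated, and the reading may reach the limit of the assay. The estimated change is the step (a 1.9-fold higher number from compound 2 to compound 3 (0.28 log units; within the scatter)). For compound 3 the estimated value is (80000 nM). The expected range for compound 3 runs from (35000 nM) to (180000 nM).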

Compound 3, half-maximal cytotoxic concentration: 13200 nM
Compound 3: middle estimate off by 6.1-fold (0.78 log units), on the high side; measured number outside the range, below it.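

The position on an aromatic carbon of the five-membered aromatic ring with 1 nitrogen and 1 oxygen now has its first readable step in this assay: dimethylcarbamoyl in place of 3,4-dimethoxyphenyl gives a 3.2-fold lower number from compound 2 to compound 3 (0.50 log units; beyond the scatter), so less compound is tolerated. In this pair, the smaller group without a ring does not bring more tolerance, and the result points the opposite way from a simple gain on removing the six-membered aromatic ring. The single step gives the direction for this one pair only, and no measurement shown gives a cause for it.

From the compounds shown here alone, whether a carboxylic acid, a primary amide or an unsubstituted phenyl ring at this position would read closer to compound 2 or to compound 3 stays open, so the step cannot yet be assigned to the loss of the ring, the loss of the methoxy groups or the arrival of the amide. For compound 1 the reading of > 100000 nM is a limit, which leaves open how the same change would read on the core of compound 1.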